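Benzyloxy in Place of Bromo: Expectation for Compound 4

A few compounds are considered here, and "the series" means these few. Any claim that something is new, unique, unknown or untested is made for them only; others in the source may bear on it.

Compound 1 `Cc1cc(O)c(C(=O)/C=C/c2ccc(F)cc2)c(-c2ccc(OCc3ccccc3)cc2)c1C(=O)/C=C/c1ccc(F)cc1`: 28000 nM
Compound 2 `Cc1cc(O)c(C(=O)/C=C/c2ccc(OCc3ccccc3)cc2)c(-c2ccc(Br)cc2)c1C(=O)/C=C/c1ccc(OCc2ccccc2)cc1`: 20000 nM
Compound 3 `Cc1cc(O)c(C(=O)/C=C/c2ccc(F)cc2)c(-c2ccc(Br)cc2)c1C(=O)/C=C/c1ccc(F)cc1`: 20000 nM

Of the compounds shown here, three have been measured in a functional assay on MCF7 cells (Homo sapiens) for cytotoxicity, read by MTT assay, with a stated time of 24 h; a lower number here means a stronger inhibitor, a higher number a weaker inhibitor. All three numbers lie within the scatter of one another, so no order among them can be read. Going from compound 3 to compound 1 the change is benzyloxy in place of bromo on an aromatic carbon, and it made a 1.4-fold higher number from compound 3 to compound 1 (0.15 log units; within the scatter). How the core of compound 2 differs from that of compound 3 is not broken down here. Compound 4 `Cc1cc(O)c(C(=O)/C=C/c2ccc(OCc3ccccc3)cc2)c(-c2ccc(OCc3ccccc3)cc2)c1C(=O)/C=C/c1ccc(OCc2ccccc2)cc1` arises from compound 2 by the same change, (benzyloxy in place of bromo on an aromatic carbon). Because that change gave a 1.4-fold higher number from compound 3 to compound 1 (0.15 log units; within the scatter), compound 4 is expected to show a step of about a 1.4-fold higher number from compound 2 to compound 4 (0.15 log units; within the scatter) in this assay. The estimate for compound 4 is 28000 nM, with a range from 10000 nM to 80000 nM.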

Compound 4, half-maximal inhibitory concentration: 26000 nM
Estimate against measurement, compound 4: 1.1-fold (0.03 log units) above; measured number inside the range.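

In this assay, benzyloxy in place of bromo gave a 1.3-fold higher number from compound 2 to compound 4 (0.11 log units; within the scatter), and set beside the earlier step, the change reads alike on the two cores: the same change on two cores in this assay, a 1.4-fold higher number (0.15 log units; within the scatter) from compound 3 to compound 1 and a 1.3-fold higher number (0.11 log units; within the scatter) from compound 2 to compound 4, 1.1-fold (0.03 log units) apart, within the scatter of two such steps. Both steps lie within the scatter, so what carries from the core of compound 3 to the core of compound 2 is the lack of a readable effect, not a gain or a loss in activity. Two cores do not show that the change would behave the same way on any other core in the series.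

The compounds shown leave open whether another group on that aromatic carbon, such as an amine or a carboxylic acid, would move the number beyond the scatter.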